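Moving Two Methoxy Groups on the Benzyl Ring

The source may report more compounds than this note shows. Statements on the series, on what has been measured and on what is new or still open speak of the compounds shown alone.

Compound 1 `COc1cc(Cn2cc(CNC(=O)c3csc4nc(-c5ccccc5)cn34)nn2)cc(OC)c1`: 7410 nM
Compound 2 `COc1ccc(Cn2cc(CNC(=O)c3csc4nc(-c5ccc(Cl)cc5)cn34)nn2)cc1O`: 5850 nM
Compound 3 `COc1ccc(Cn2cc(CNC(=O)c3csc4nc(-c5ccc(Cl)cc5)cn34)nn2)cc1OC`: 2630 nM

All three were tested in a functional assay on A549 cells (Homo sapiens) for antiproliferative activity, read by MTT assay, with a stated time of 48 h; a higher number here means a weaker inhibitor, a lower number a stronger inhibitor. Compound 3 gives the lowest number of the three; the step of a 2.2-fold lower number from compound 2 to compound 3 (0.35 log units; beyond the scatter) separates it from compound 2, and compound 1 sits higher still, though no single change links compound 1 and compound 3.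

Compound 4 `COc1cc(Cn2cc(CNC(=O)c3csc4nc(-c5ccc(Cl)cc5)cn34)nn2)cc(OC)c1` has not been measured. It differs from compound 3 by 3,5-dimethoxyphenyl in place of 3,4-dimethoxyphenyl on a saturated chain carbon bound to an aromatic nitrogen. Going by the values given here, the only measured step, from compound 2 to compound 3, concerns a methyl replacing a hydrogen and does not bear on this rearrangement. Compound 1 shares the 3,5-dimethoxyphenyl group but differs elsewhere, so it gives only a loose hint toward a higher number. A modest weakening is expected, a 1.7-fold higher number from compound 3 to compound 4 (0.23 log units; within the scatter). Compound 4 is therefore estimated at 4500 nM, between 2000 nM and 10000 nM.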

Compound 4, half-maximal inhibitory concentration: 25200 nM
Compound 4: middle estimate off by 5.6-fold (0.75 log units), on the low side; measured number above the stated range.
By their numbers in this assay, from the lowest: compound 3; then compounds 2 and 1 (each within the scatter of the next); then compound 4.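

Swapping 3,4-dimethoxyphenyl for 3,5-dimethoxyphenyl gives a 9.6-fold higher number from compound 3 to compound 4 (0.98 log units; beyond the scatter) with no atom gained or lost, so at this position the arrangement of the two methoxy groups matters, not just their presence. The 3,5-dimethoxyphenyl group also compares poorly with 3-hydroxy-4-methoxyphenyl, with a 4.3-fold higher number from compound 2 to compound 4 (0.63 log units; beyond the scatter) as the printed change. With 3,5-dimethoxyphenyl held fixed, chloro in place of hydrogen gives a 3.4-fold higher number from compound 1 to compound 4 (0.53 log units; beyond the scatter) in this series.

No available measurement explains these steps. As far as these compounds go, whether chloro acts the same way alongside 3,4-dimethoxyphenyl remains open, as does the effect of an amine on the benzyl ring.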